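The source may hold more compounds than are shown below. What is called first, only, known or untested is meant among the compounds shown, and "the series" means these compounds.

Measured compounds:
- compound 1, `O=C(CCSc1nc(-c2ccccc2)co1)N1CCCC1`: "not determined" (no result reported) in an ADME assay on microsomes from liver (Mus musculus) for metabolic stability, read by LC-MS, using NADPH, with a stated time of 45 min, tested at 0.5 uM; a lower number here means slower removal, a higher number faster removal of the compound
- compound 2, `O=C(CCSc1nc2cc(F)c(F)cc2o1)N1CCCC1`: 45.9 mL/min/g
- compound 3, `O=C(CCSc1nc2cc(Cl)ccc2o1)NC1CCCC1`: "not determined" (no result reported)

For the measured compounds named here, compound 3 stands without a number in this assay, and compound 1 likewise has none, so the only measured point is compound 2, which gives 45.9 mL/min/g. Compound 4, `O=C(CCSc1nc2cc(Cl)ccc2o1)N1CCC1`, differs from compound 3 by azetidin-1-yl in place of cyclopentylamino on a carbonyl carbon. Going by the values given here, with no measured step between any two compounds, no direction can be drawn from the data; the change is a swap of one small amide substituent for another, and a step within the scatter of this assay is as likely as one beyond it in either direction. On that basis compound 4 is expected to show 40 mL/min/g in this assay, estimated to fall between 15 mL/min/g and 100 mL/min/g.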

Compound 4, intrinsic clearance in a liver preparation (reported as CLH), per the amount of preparation that the assay uses: 17.9 mL/min/g
Beside the measured number, compound 4's estimate is 2.2-fold (0.35 log units) above it, within the range that was stated.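

For the compounds shown here, compound 3 has no single number in this assay, so no step to compound 4 can be read. The compounds shown leave open how replacing cyclopentylamino with azetidin-1-yl changes removal in this preparation. No supporting measurement bears on this result.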